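The source may hold more compounds than are shown below. What is called first, only, known or untested is meant among the compounds shown, and "the series" means these compounds.

Measured so far in a functional assay on MDA-MB-231 cells (Homo sapiens) for inhibition, read by MTT assay, with a stated time of 72 h; a higher number here means a weaker inhibitor, a lower number a stronger inhibitor:

Compound 1, `CC(C)(C)n1cc2c(n1)C(=O)CC1(CCN(C(=O)c3cc(-c4ccc(Cl)cc4)nc4ccccc34)CC1)O2`, gives > 10000 nM.
Compound 2, `COc1ccc(-c2cc(C(=O)N3CCC4(CC3)CC(=O)c3nn(C(C)(C)C)cc3O4)c3ccccc3n2)cc1`, gives > 10000 nM.
Compound 3, `CC(C)(C)n1cc2c(n1)C(=O)CC1(CCN(C(=O)c3cc(Cl)nc4ccccc34)CC1)O2`, gives 9220 nM.

The value for compound 1 is a limit of this assay, not a number. The value for compound 2 is likewise a limit. Only compound 3 gives a number in this assay.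

Compound 1 and compound 3 share most of their structure and differ in one place: chloro in place of 4-chlorophenyl on an aromatic carbon. This gives an at least 1.0-fold lower number from compound 1 to compound 3 (0.03 log units; that floor lies within the scatter). The same swap from compound 2 gives an at least 1.0-fold lower number from compound 2 to compound 3 (0.03 log units; that floor lies within the scatter). Between compound 1 and compound 2 the difference is methoxy in place of chloro on an aromatic carbon, and a step that the two limits leave unreadable from compound 1 to compound 2 because of the limit of > 10000 nM in this assay, at which 2 of the 3 values shown sit.

Compound 4, `COc1cc(C(=O)N2CCC3(CC2)CC(=O)c2nn(C(C)(C)C)cc2O3)c2ccccc2n1`, has not yet been measured in this assay. It differs from compound 3 in one place: methoxy in place of chloro on an aromatic carbon. Among the compounds with values here, this is the same kind of change as the one from compound 1 to compound 2, but not at the same place: in compound 1 the swap sits on a six-membered aromatic ring of carbon only, para to a large group, while in compound 3 it sits on a six-membered aromatic ring with 1 nitrogen, part of a fused system of two rings, next to the ring nitrogen. The earlier step gave no readable size, so it sets no expectation of its own. Resting on compound 3 giving 9220 nM, compound 4 is expected to show a 1.2-fold higher number from compound 3 to compound 4 (0.08 log units; within the scatter). Compound 4 is estimated at 11000 nM, within 4500 nM to 30000 nM, with a fair chance that this assay reports only a limit.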

Compound 4, half-maximal inhibitory concentration: > 10000 nM
Compound 4: only a limit was reported; the forecaster's own chance of this, stated with the estimate: 55%; the middle value lies beyond the limit too.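

In this assay compound 4 gives > 10000 nM, which is a limit of the assay and not a number. Methoxy in place of chloro on the ring with one nitrogen gives an at least 1.0-fold higher number from compound 3 to compound 4 (0.03 log units; that floor lies within the scatter), so this change shows no readable gain or loss so far, although the true size of the step may be larger than that floor. The same change on the carbon-only ring of compound 1 cannot be set beside it, and the steps from compound 1 and compound 2 to compound 4 cannot be read either, so nothing shows whether the change carries the same size from one place to the other, because three of the four compounds end at the same limit: the limit of > 10000 nM in this assay, at which 3 of the 4 values shown sit.

Within the data shown here, compound 3 is the only compound with a number, and chloro and methoxy alone leave open what other groups on this aromatic carbon of the shared core would give. An amine, a carboxylic acid or a longer chain such as ethoxy could show whether any replacement there brings the number clearly under the limit in this assay.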